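Ortho-substituted phenoxypiperidines: cyano to bromo

The source may hold more compounds than are shown below. What is called first, only, known or untested is meant among the compounds shown, and "the series" means these compounds.

Measured so far in an assay on microsomes from liver for inhibition of acyl-CoA desaturase 1 (Rattus norvegicus); a lower number here means a stronger inhibitor, a higher number a weaker inhibitor:
compound 1 `CC(C)(C)c1nnc(-c2ccc(N3CCC(Oc4ccccc4C(F)(F)F)CC3)nn2)o1` gives 980 nM
compound 2 `N#Cc1ccccc1OC1CCN(c2ccc(-n3ccnc3)nn2)CC1` gives 236 nM

Compound 2 holds the lowest of the two numbers in this assay. Compound 1, which carries a different group on the same shared core and a different ring on the far end, gives a higher number; that gap is beyond the scatter, but the two compounds differ in more than one place, so no single change can be read from it.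

Compound 3 `Brc1ccccc1OC1CCN(c2ccc(-n3ccnc3)nn2)CC1` is not yet measured in this assay. It differs from compound 2 by bromo in place of cyano on an aromatic carbon. Among the measured compounds shown here, no measured pair shows this exchange, so nothing tells how large a step to expect. The working expectation is a step of a 1.4-fold higher number from compound 2 to compound 3 (0.13 log units; within the scatter) that stays within the scatter, with a slight lean toward a higher number. Compound 3 is therefore expected to give about 320 nM, in a range from 110 nM to 950 nM.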

Compound 3, half-maximal inhibitory concentration: 5 nM
For compound 3 the middle estimate is 64-fold (1.81 log units) above the measured one, and the stated range ends above it.
By their numbers in this assay, from the lowest: compound 3; then compound 2; then compound 1.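

In this assay, among the compounds shown here, bromo in place of cyano on an aromatic carbon, ortho to a large group, gives a 47-fold lower number from compound 2 to compound 3 (1.67 log units; beyond the scatter) and is the only single-place comparison so far. With the rest of the structure unchanged, the identity of the group at this place alone moves the number well beyond the scatter, so the position is far from indifferent to this exchange. Nothing in hand accounts for the size of the step.

Whether this low number is particular to bromo remains open, since chloro, methoxy and an amine on the same aromatic carbon are not among the compounds shown. For the compounds shown here, also open is whether the step carries over to the far-end ring of compound 1, as no pair shows bromo with that ring.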